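The source may report more compounds than this note shows. Statements on the series, on what has been measured and on what is new or still open speak of the compounds shown alone.

Measured so far in a functional assay on HBL-100 cells (Homo sapiens) for cytotoxicity, read by MTT assay, with a stated time of 72 h; on this read-out higher numbers stand for weaker inhibition and lower numbers for stronger inhibition:
compound 1 `C#CCn1cc(C(=O)NC(CC(=O)Nc2ccccc2)c2ccccc2)c(=O)c2cccnc21`: > 10000 nM
compound 2 `C#CCn1cc(C(=O)NC(CC(=O)NC2CCCCC2)c2ccccc2)c(=O)c2cc(F)c(Cl)nc21`: > 10000 nM

The value of compound 1 in this assay is a limit, not a number. The value of compound 2 in this assay is likewise a limit. Compound 3 `C#CCn1cc(C(=O)NC(CC(=O)Nc2ccccc2)c2ccccc2)c(=O)c2ccc(Cl)nc21` differs from compound 1 by chloro in place of hydrogen on an aromatic carbon. Within the data shown here, no measured pair separated by one change is available, and the only evidence is the limit of > 10000 nM in this assay, at which 2 of the 2 values shown sit. The expected step that the limit leaves unreadable from compound 1 to compound 3 is therefore none beyond the scatter. Compound 3 is estimated at 15000 nM in this assay, with a range from 4000 nM to 50000 nM.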

Compound 3, half-maximal inhibitory concentration: 4000 nM
Compound 3: the middle estimate sits 3.8-fold (0.57 log units) above what was measured; low and high end bracket the measured number.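

In this assay, chloro next to the ring nitrogen gives an at least 2.5-fold lower number from compound 1 to compound 3 (0.39 log units; beyond the scatter), so this position can change the read-out, and this single added atom is enough to do so. Compound 1 sits at a limit rather than a number, so this step gives only a minimum size: the limit of > 10000 nM in this assay, at which 2 of the 3 values shown sit.

The compounds shown leave open whether chloro is special here or whether other groups at this place would act alike, such as an amine or a methoxy group. They also leave open whether the step holds on other versions of the shared core.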